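Thioether Side Chain Variation on the Shared Core

The compounds below may be only part of what the source reports. "The series", "measured", "known", "first", "only" and "open" are said of these compounds alone.

Measured so far in an assay on HEK293 cells for displacement of a labelled ligand from prostaglandin D2 receptor 2 (Homo sapiens); a higher number here means a weaker inhibitor, a lower number a stronger inhibitor:
compound 1 `O=C(O)Cn1c(SCCCc2ccccc2)nc2ccccc21`: 475 nM
compound 2 `CCOC(=O)CCSc1nc2ccccc2n1CC(=O)O`: 11400 nM
compound 3 `CCOC(=O)CCCCCSc1nc2ccccc2n1CC(=O)O`: 1010 nM

Compound 2 stands highest of the three numbers; nearest is the step of an 11-fold lower number from compound 2 to compound 3 (1.05 log units; beyond the scatter), and furthest the step of a 24-fold higher number from compound 1 to compound 2 (1.38 log units; beyond the scatter). Compound 4 `Cc1ccc(CSc2nc3ccccc3n2CC(=O)O)cc1` differs from compound 2 by 4-methylphenyl in place of (ethoxycarbonyl)methyl on a saturated chain carbon bound to a sulfur. Within the data shown here, two measured steps bear on this. Removing the ester-bearing chain in favour of an aromatic ring reversed the large loss seen in a 24-fold higher number from compound 1 to compound 2 (1.38 log units; beyond the scatter), and even lengthening the ester chain gave an 11-fold lower number from compound 2 to compound 3 (1.05 log units; beyond the scatter). A large downward step is therefore expected in this assay, a 14-fold lower number from compound 2 to compound 4 (1.15 log units; beyond the scatter). Compound 4 is estimated at 800 nM, with a range from 200 nM to 4000 nM.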

Compound 4, half-maximal inhibitory concentration: 220 nM
Compound 4: middle estimate off by 3.6-fold (0.56 log units), on the high side; measured number inside the range.
By their numbers in this assay, from the lowest: compound 4; then compound 1; then compound 3; then compound 2.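

In this assay, a 52-fold lower number from compound 2 to compound 4 (1.71 log units; beyond the scatter) shows that this position tolerates a carbon-only aromatic ring placed directly on the saturated chain carbon bound to a sulfur, and the entering group has no hydrogen-bond acceptors. Of the four compounds, the lowest number now belongs to an aryl group on this short chain, not to a longer chain. No evidence on the cause of this step is available.

Open, from the compounds shown here alone, is how a plain phenyl or a 4-chlorophenyl on that same carbon would compare with 4-methylphenyl. Also open, going by these compounds, is whether an amine or a carboxylic acid on the ring would keep the number this low.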